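From Thiophene to Imidazole: An Expected Loss of Potency

The source may report more compounds than this note shows. Statements on the series, on what has been measured and on what is new or still open speak of the compounds shown alone.

Three measured compounds share one core and differ only in the aromatic ring attached to it. In a functional assay for activation of Alpha-1A adrenergic receptor (Homo sapiens), read by calcium flux (a lower number here means that less compound is needed, a higher number that more compound is needed for the effect), compound 3 `c1ccc(-c2ccsc2)c(OCC2=NCCN2)c1` gives 0.251 nM, the lower of the two numbers reported. Compound 2 `c1csc(-c2ccccc2OCC2=NCCN2)c1` gives 1 nM in this assay, and the step of a 4.0-fold lower number from compound 2 to compound 3 (0.60 log units; beyond the scatter) is modest but beyond the scatter. Compound 1 `c1ccc(-c2ccncn2)c(OCC2=NCCN2)c1` returns only a limit of the assay, < 100000 nM (the limit of < 100000 nM in this assay, at which 1 of the 3 values shown sits). Because of that limit, the steps a step that the limit leaves unreadable from compound 1 to compound 2 and a step that the limit leaves unreadable from compound 1 to compound 3 cannot be sized.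

Compound 4 `c1ccc(-c2ncc[nH]2)c(OCC2=NCCN2)c1` has not yet been measured. It differs from compound 3 by 1H-imidazol-2-yl in place of thiophen-3-yl on an aromatic carbon. Within the data shown here, no readable step exchanges one five-membered ring for another with a different set of hetero atoms; the only steps that involve a ring with nitrogen start from the limit of compound 1 and say nothing about size. Among the measured compounds shown here, the one readable step, a 4.0-fold lower number from compound 2 to compound 3 (0.60 log units; beyond the scatter), shows that even moving the point of attachment on the same ring shifts the number beyond the scatter, so a larger change of ring is expected to matter more. Compound 4 is therefore expected to give a higher number in this assay, estimated at 50 nM with a range of 2 nM to 2000 nM. That estimate means an expected step of a 200-fold higher number from compound 3 to compound 4 (2.30 log units; beyond the scatter), held with low confidence.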

Compound 4, half-maximal effective concentration: 100 nM
Compound 4: the middle estimate sits 2.0-fold (0.30 log units) below what was measured; low and high end bracket the measured number.
By their numbers in this assay, from the lowest: compound 3; then compound 2; then compound 4.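

In this assay, a five-membered ring carrying nitrogen now has a readable effect at this position: 1H-imidazol-2-yl in place of thiophen-3-yl gives a 400-fold higher number from compound 3 to compound 4 (2.60 log units; beyond the scatter), and in place of thiophen-2-yl it gives a 100-fold higher number from compound 2 to compound 4 (2.00 log units; beyond the scatter). Both steps are much larger than the change between the two thiophene attachments, a 4.0-fold lower number from compound 2 to compound 3 (0.60 log units; beyond the scatter), even though the entering and leaving rings have the same number of heavy atoms and neither carries a net charge, so the identity of the ring counts for far more here than its size. Compound 1 remains a limit of the assay, which is why its step to compound 4 cannot be read, like its steps to the other compounds, and the size of the difference between pyrimidin-4-yl and 1H-imidazol-2-yl stays unknown: the limit of < 100000 nM in this assay, at which 1 of the 4 values shown sits.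

The imidazole differs from the thiophenes both in replacing sulfur with two nitrogens and in adding a hydrogen-bond donor, and the compounds shown cannot separate these two changes. A 1-methylimidazol-2-yl group, a pyrrol-2-yl group or a furan-2-yl group at this position would be needed to tell them apart, and none of these is among the compounds shown.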